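From Compound 2 to Compound 4: A Smaller Substituent

The source may hold more compounds than are shown below. What is called first, only, known or untested is meant among the compounds shown, and "the series" means these compounds.

The study covers a small set of compounds tested in a functional assay on Ramos cells (Homo sapiens) for antiproliferative activity, read by CCK-8 assay, with a stated time of 24 h; on this read-out lower numbers stand for stronger inhibition and higher numbers for weaker inhibition. Compound 1 `C=CC(=O)Nc1cccc(Nc2nc(N)nc(Nc3ccc(Oc4ccccc4)cc3)n2)c1` gives 20000 nM in this assay, and compound 3 `CC#CC(=O)Nc1cccc(Nc2ncnc(Nc3ccc(C(=O)N4CCCCC4)cc3)n2)c1` gives 24400 nM in this assay; these two values lie within the usual scatter of each other, so neither can be placed above the other. Compound 2 `C=CC(=O)Nc1cccc(Nc2ncnc(Nc3ccc(-c4ccc(C)nc4)cc3)n2)c1` gives "not determined" (no result reported) in this assay, so no number marks where it stands among the measured compounds. Compound 4 `C=CC(=O)Nc1cccc(Nc2ncnc(Nc3ccc(OC)cc3)n2)c1` has not yet been measured. It differs from compound 2 by methoxy in place of 6-methylpyridin-3-yl on an aromatic carbon. For the measured compounds named here, no step between measured compounds is available to guide the size of this change, and the two measured values are weak and close together, so no step beyond the scatter in either direction is expected in this assay. Compound 4 is therefore expected to give about 22000 nM in this assay, with an estimated range from 8000 nM to 60000 nM. Both measured values are weak, and the expectation for compound 4 is a weak value of the same order.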

Compound 4, half-maximal inhibitory concentration: 90000 nM
For compound 4 the middle estimate is 4.1-fold (0.61 log units) below the measured one; measured number outside the range, above it.
By their numbers in this assay, from the lowest: compounds 1 and 3 (each within the scatter of the next); then compound 4.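

No new step can be read from compound 4, as compound 2, which differs from it in one place, has no number to compare. No measured evidence bears on this result. The compounds shown leave open what replacing 6-methylpyridin-3-yl with methoxy does to the read-out.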